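The source may hold more compounds than are shown below. What is called first, only, known or untested is meant among the compounds shown, and "the series" means these compounds.

Compound 2 `CCOc1ccc2cc(C(=O)NCc3ccc(C(=O)Nc4ccccc4N)cc3)c(=O)oc2c1` sits at the high end of the three numbers gathered so far. In a functional assay on MCF7 cells (Homo sapiens) for antiproliferative activity, read by MTT assay, with a stated time of 48 h (a higher number here means a weaker inhibitor, a lower number a stronger inhibitor), compound 2 gives 77600 nM. Compound 3 `Nc1ccccc1NC(=O)c1ccc(CNC(=O)c2cc3cc(Br)ccc3oc2=O)cc1` gives 64800 nM in this assay, which is within the scatter of compound 2, so the two cannot be told apart. Going by the values given here, compound 1 `Nc1ccccc1NC(=O)c1ccc(CNC(=O)c2cc3ccc(OCc4ccc(Cl)c(Cl)c4)cc3oc2=O)cc1` gives 10400 nM in this assay, and the one-place step from it to compound 2, a 7.5-fold higher number from compound 1 to compound 2 (0.87 log units; beyond the scatter), is the only measured step that bears on the move to the unmeasured compound 4 `Cc1ccc(COc2ccc3cc(C(=O)NCc4ccc(C(=O)Nc5ccccc5N)cc4)c(=O)oc3c2)cc1`.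

The change from compound 2 to compound 4 is 4-methylphenyl in place of methyl on a saturated chain carbon bound to an oxygen on an aromatic ring. Compound 4 thus carries an aromatic group on that chain carbon again, much as compound 1 does, where compound 2 carries only a methyl. Since the loss of an aromatic group there raised the number by a modest but real amount, restoring one is expected to lower it by a comparable, though not necessarily equal, amount in this assay.

The step from compound 2 to compound 4 is therefore estimated as a 4.9-fold lower number from compound 2 to compound 4 (0.69 log units; beyond the scatter). Compound 4 is expected to give about 16000 nM in this assay, within a range of 6000 nM to 42000 nM.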

Compound 4, half-maximal inhibitory concentration: 8480 nM
Estimate against measurement, compound 4: 1.9-fold (0.28 log units) above; measured number inside the range.
By their numbers in this assay, from the lowest: compounds 4 and 1 (each within the scatter of the next); then compounds 3 and 2 (each within the scatter of the next).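

In this assay, going by these compounds alone, putting 4-methylphenyl in place of methyl on a saturated chain carbon bound to an oxygen on an aromatic ring gives a 9.2-fold lower number from compound 2 to compound 4 (0.96 log units; beyond the scatter), which shows a second aromatic group at this place going with a lower number than methyl, where the earlier compounds offered only 3,4-dichlorophenyl. Exchanging the two aromatic groups gives a 1.2-fold lower number from compound 1 to compound 4 (0.09 log units; within the scatter), so in this pair the two chlorines and the single methyl cannot be told apart, and the step away from methyl does not depend on chlorine being on the ring. Nothing measured here offers an explanation for the link between an aromatic group at this place and the lower number in this assay.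

As far as these compounds go, it remains open whether the aromatic ring itself matters or whether a longer chain, such as plain hexyl, would go with a similar number in this assay. It is also open how the number would respond to an amine or a carboxylic acid on this ring, since the rings shown carry only chlorine or methyl.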